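Carboxypyridinyl in place of pyrazolyl on the shared core

The compounds below may be only part of what the source reports. "The series", "measured", "known", "first", "only" and "open" are said of these compounds alone.

Compound 1 `CCC(C)(C)Cc1c[nH]c(CCc2ccc(-n3cccn3)cc2)n1` was tested in a functional assay on HEK293 cells for agonist activity at Bombesin receptor subtype-3 (Mus musculus), read by luminescence and calcium flux, with a stated time of 10 min (on this read-out higher numbers stand for an effect only at larger amounts of compound and lower numbers for an effect already at smaller amounts), where compound 1 gives 9 nM. Among the compounds with values here, of the two numbers measured so far this is the higher one; its nearest neighbour is compound 2 `CCC(C)(C)Cc1c[nH]c(CCc2ccc(-c3cnsc3)cc2)n1`, which in this assay gives 6.9 nM. The step between them, a 1.3-fold lower number from compound 1 to compound 2 (0.12 log units; within the scatter), lies within the scatter, so neither compound can be called the more active.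

Compound 3 `CCC(C)(C)Cc1c[nH]c(CCc2ccc(-c3cccnc3C(=O)O)cc2)n1` has not yet been measured. It differs from compound 1 in one place: 2-carboxypyridin-3-yl in place of 1H-pyrazol-1-yl on an aromatic carbon. Within the data shown here, the only measured step, from compound 1 to compound 2, exchanged one five-membered aromatic ring for another and left the number essentially unchanged; it is the sole guide available. Among the measured compounds shown here, the change to compound 3 is of a different kind, bringing in a six-membered ring bearing a carboxylic acid, and no measured step shows how such a group fares on this aromatic carbon. Compound 3 is therefore expected to give 40 nM in this assay, within a range from 8 nM to 200 nM. The step this estimate implies, a 4.4-fold higher number from compound 1 to compound 3 (0.65 log units; beyond the scatter), is expected to be a modest loss, held with low confidence.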

Compound 3, half-maximal effective concentration: 14 nM
For compound 3 the middle estimate is 2.9-fold (0.46 log units) above the measured one; low and high end bracket the measured number.
By their numbers in this assay, from the lowest: compounds 2, 1 and 3 (each within the scatter of the next, the first and the last beyond it).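

Within the data shown here, on the aromatic carbon para to a large group, the earlier compounds showed only one five-membered aromatic ring exchanged for another, whereas compound 3 places a six-membered aromatic ring bearing a carboxylic acid there, and in this assay this exchange gives a 1.6-fold higher number from compound 1 to compound 3 (0.19 log units; within the scatter) and so cannot be told apart from no change on the shared core. Measured against the 1,2-thiazol-4-yl group instead, the same ring gives a 2.0-fold higher number from compound 2 to compound 3 (0.31 log units; beyond the scatter) as a modest step, the only separation beyond the scatter among the three compounds, although compound 1 and compound 2 cannot themselves be told apart. Nothing at hand explains why the carboxylic acid is accepted at this place.

The compounds shown leave open whether the carboxylic acid plays any part in this result, since the outcome with a plain pyridin-3-yl ring, a methyl ester or a primary amide on this carbon remains unknown. They also leave open whether the acid would be accepted as well on a phenyl ring, or on the shared core with a shorter chain in place of the branched alkyl chain.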